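The compounds below may be only part of what the source reports. "The series", "measured", "known", "first", "only" and "open" are said of these compounds alone.

Two compounds share one core in a functional assay on SNB-19 cells (Homo sapiens) for inhibition, read by sulforhodamine B assay, with a stated time of 48 h; a lower number here means a stronger inhibitor of growth, a higher number a weaker inhibitor of growth. Compound 1 `O=C(Nc1cccc(-n2cc(-c3ccncc3)c(-c3ccc(Cl)c(O)c3)n2)c1)Nc1cccc(C(F)(F)F)c1` gives 1910 nM there. Among the compounds with values here, compound 2 `COc1cc(-c2nn(-c3cccc(NC(=O)Nc4ccc(Cl)c(C(F)(F)F)c4)c3)cc2-c2ccncc2)ccc1Cl` gives 1240 nM in this assay, and this number sits within the usual scatter of the one for compound 1, so the two cannot be told apart on these data. Compound 3 `O=C(Nc1cccc(-n2cc(-c3ccncc3)c(-c3ccc(Cl)c(O)c3)n2)c1)Nc1ccc(Cl)c(C(F)(F)F)c1` is the next compound and has not yet been measured in this assay. It differs from compound 2 in a single place: hydrogen in place of methyl on an oxygen on an aromatic ring. Within the data shown here, no measured pair shows this change on its own, so its effect is not known from these data. Compound 3 is therefore expected to land close to compound 2, with the step from compound 2 to compound 3 estimated as a 1.2-fold higher number from compound 2 to compound 3 (0.08 log units; within the scatter), which is within the scatter in either direction. The estimate for compound 3 in this assay is 1500 nM, with a range from 600 nM to 3800 nM.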

Compound 3, concentration for 50% growth inhibition: 1120 nM
Estimate against measurement, compound 3: 1.3-fold (0.13 log units) above, within the range that was stated.
By their numbers in this assay, from the lowest: compounds 3, 2 and 1 (each within the scatter of the next).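

Hydrogen in place of methyl on an oxygen on an aromatic ring gives a 1.1-fold lower number from compound 2 to compound 3 (0.04 log units; within the scatter) in this assay and so, at this position, methoxy and hydroxy cannot be told apart. Chloro in place of hydrogen on an aromatic carbon, on the other side of the urea, gives a 1.7-fold lower number from compound 1 to compound 3 (0.23 log units; within the scatter) and this change cannot be told from no change either. No other data bear on these results.

The compounds shown leave open whether any group on this oxygen-bearing carbon can shift the number beyond the scatter, as an amine, a carboxylic acid or a longer chain such as butoxy might. They also leave open whether the same small steps would hold with a different group in place of the chloro.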